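Replacing 1H-imidazol-1-yl in compound 2: working notes

This account rests on a few compounds, and the source may have more. Where it says the series, first, only, none or still open, it means among the compounds named here.

In an ADME assay on microsomes from liver (Mus musculus) for metabolic stability, read by LC-MS, using NADPH, with stated times of 10 min and 30 min, tested at 1 uM (a higher number here means faster removal of the compound, a lower number slower removal), compound 2 `COC(=O)C1=C(Cn2ccnc2)NC(c2nccs2)=NC1(C)c1ccc(F)cc1` gives 69 mL/min/kg, within the scatter of compound 1 `COC(=O)C1=C(CN2CCNCC2)NC(c2nccs2)=NC1(C)c1ccc(F)cc1`, which gives 39 mL/min/kg. Compound 3 `COC(=O)C1=C(COC(C(=O)O)C(F)(F)F)NC(c2nccs2)=NC1(C)c1ccc(F)cc1` differs from compound 2 by a group of 9 heavy atoms (3 carbon, 3 oxygen, 3 fluorine; no ring) in place of a group of 5 heavy atoms (3 carbon, 2 nitrogen; one five-membered aromatic ring with 2 hetero atoms), on a saturated chain carbon bound to a double-bonded ring carbon. Going by the values given here, only one measured step bears on this place: a 1.8-fold higher number from compound 1 to compound 2 (0.25 log units; within the scatter), and it stays within the scatter. Among the compounds with values here, it is a weak guide, as the entering group has no ring and the data hold no measured compound with a group of this kind at this place. Within the data shown here, no step clearly beyond the scatter is therefore expected in this assay, and the expected change is a 1.7-fold lower number from compound 2 to compound 3 (0.24 log units; within the scatter). The direction of this expected step remains uncertain. For compound 3, the estimated value is 40 mL/min/kg, with an expected range of 15 mL/min/kg to 90 mL/min/kg.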

Compound 3, clearance: 24 mL/min/kg
Beside the measured number, compound 3's estimate is 1.7-fold (0.22 log units) above it; the range from low to high includes it.
By their numbers in this assay, from the lowest: compounds 3, 1 and 2 (each within the scatter of the next, the first and the last beyond it).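

In this assay, going by these compounds alone, the group of 9 heavy atoms with no ring gives a 2.9-fold lower number from compound 2 to compound 3 (0.46 log units; beyond the scatter), the first step at this place, on a saturated chain carbon bound to a double-bonded ring carbon, to lie beyond the scatter. Set against piperazin-1-yl, the same group gives a 1.6-fold lower number from compound 1 to compound 3 (0.21 log units; within the scatter), so the change is clear only against 1H-imidazol-1-yl. No measurement bears on what lies behind this step.

The compounds shown leave open which part of the entering group goes with the lower number, as its carboxylic acid and trifluoromethyl change together in a single step. A primary amide in place of the carboxylic acid, or a plain methyl in place of the trifluoromethyl, would separate the two.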